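From 3-Chloropropyl to a Larger Side Chain

The source may report more compounds than this note shows. Statements on the series, on what has been measured and on what is new or still open speak of the compounds shown alone.

Among the measured compounds shown here, compound 1 `O=c1cc(Cn2cc(CCCCl)nn2)c2ccc(O)cc2o1` is the only compound in this set with a full number: in a functional assay on SW-620 cells (Homo sapiens) for inhibition, read by MTT assay, with a stated time of 72 h (a lower number here means a stronger inhibitor, a higher number a weaker inhibitor), compound 1 gives 59800 nM. Compound 2 `CC(C)(C)c1cn(Cc2cc(=O)oc3cc(O)ccc23)nn1` carries tert-butyl in place of 3-chloropropyl on an aromatic carbon. In this assay compound 2 reaches only > 100000 nM, which is a limit of the assay and not a number (the limit of > 100000 nM in this assay, at which 1 of the 2 values shown sits). The step of an at least 1.6-fold higher number from compound 1 to compound 2 (0.22 log units; that floor lies within the scatter) thus has only a floor, and that floor lies within the scatter, so it gives no direction. Compound 3 `O=c1cc(Cn2cc(CSC(=S)N3CCOCC3)nn2)c2ccc(O)cc2o1` alters the same chain of the shared core: a group of 9 heavy atoms (5 carbon, 1 nitrogen, 1 oxygen, 2 sulfur; one six-membered non-aromatic ring with 2 hetero atoms) in place of a group of 3 heavy atoms (2 carbon, 1 chlorine; no ring), on a saturated chain carbon bound to an aromatic carbon. For the measured compounds named here, the only measured step at this chain is the one just described, and it is too small to guide a direction, so for compound 3 the expected step is a 1.1-fold lower number from compound 1 to compound 3 (0.04 log units; within the scatter), with a wide range in either direction. Compound 3 is therefore estimated at 55000 nM, between 15000 nM and 150000 nM.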

Compound 3, half-maximal inhibitory concentration: >= 100000 nM
Compound 3 was reported as a limit (the forecaster's own chance of this, stated with the estimate: 35%); at least 1.8-fold (0.25 log units) between middle value and limit.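

In this assay, compound 3 gives a limit of the assay and not a number: the limit of >= 100000 nM in this assay, at which 1 of the 3 values shown sits.

The step therefore has only a floor, an at least 1.6-fold higher number from compound 1 to compound 3 (0.22 log units; that floor lies within the scatter), and it fixes neither a size nor a direction for this change. What compound 3 adds is a second, quite different replacement that also gives no full number: a group of 9 heavy atoms with one six-membered non-aromatic ring, on a saturated chain carbon bound to an aromatic carbon, ends at a limit just as tert-butyl does in compound 2.

Going by these compounds, it remains open how an amine, a carboxylic acid or a longer unbranched chain in place of the 3-chloropropyl group would read in this assay. Also open, on these data alone, is whether compound 2 and compound 3 truly differ from compound 1 by more than the scatter.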